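Aryl versus alkyl amines on the shared core, cytotoxicity

This account rests on a few compounds, and the source may have more. Where it says the series, first, only, none or still open, it means among the compounds named here.

Measured compounds:
- compound 1, `Cc1cc(NC(C)C)nc(SCc2nc3ccccc3[nH]2)n1`: > 100000 nM in a functional assay on PC-3 cells (Homo sapiens) for cytotoxicity, read by MTT assay, with a stated time of 72 h; on this read-out higher numbers stand for weaker inhibition and lower numbers for stronger inhibition
- compound 2, `Cc1cc(Nc2ccc(Cl)cc2)nc(SCc2nc3ccccc3[nH]2)n1`: 36000 nM
- compound 3, `Cc1cc(NCCO)nc(SCc2nc3ccccc3[nH]2)n1`: > 100000 nM

Compound 3 gives only a limit in this assay, > 100000 nM, and not a number. Compound 1 also sits at a limit, > 100000 nM; the line the limit of > 100000 nM in this assay, at which 2 of the 3 values shown sit, holds two of the three values shown. Among the compounds with values here, compound 2 is the one member that gives a number, and the two steps that end or start at a limit read as follows: an at least 2.7-fold lower number from compound 1 to compound 2 (0.44 log units; beyond the scatter), and an at least 2.7-fold higher number from compound 2 to compound 3 (0.44 log units; beyond the scatter). The step that the two limits leave unreadable from compound 1 to compound 3.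

Compound 4, `Cc1cc(Nc2ccc(Br)cc2)nc(SCc2nc3ccccc3[nH]2)n1`, is the next member. It differs from compound 3 in one place: 4-bromophenyl in place of 2-hydroxyethyl on a nitrogen on an aromatic ring. Within the data shown here, the nearest measured step is the one from compound 2 to compound 3, in which a 4-chlorophenyl on the same nitrogen was exchanged for 2-hydroxyethyl and the number rose at least modestly. The change to compound 4 runs the other way and brings in a 4-bromophenyl, so a fall of similar size is expected, an at least 2.5-fold lower number from compound 3 to compound 4 (0.39 log units; beyond the scatter). Compound 4 is therefore expected to land near compound 2, at 40000 nM, within 15000 nM to 100000 nM.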

Compound 4, half-maximal inhibitory concentration: 37100 nM
Estimate against measurement, compound 4: 1.1-fold (0.03 log units) above, and the stated range covers the measured number.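

Swapping the halogen adds little: bromo in place of chloro on an aromatic carbon gives a 1.0-fold higher number from compound 2 to compound 4 (0.01 log units; within the scatter) in this assay, so the two halogenated aryl amines cannot be told apart on this read-out. The second aryl amine also stands clear of both alkyl members, with an at least 2.6-fold lower number from compound 3 to compound 4 (0.43 log units; beyond the scatter) for 4-bromophenyl in place of 2-hydroxyethyl and an at least 2.6-fold lower number from compound 1 to compound 4 (0.43 log units; beyond the scatter) for 4-bromophenyl in place of isopropyl, so the separation on this nitrogen no longer rests on the 4-chlorophenyl member alone. The size of that separation can still be stated only as a minimum: the limit of > 100000 nM in this assay, at which 2 of the 4 values shown sit.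

As far as these compounds go, whether the aromatic ring alone accounts for the separation, or whether the halogen on it is also needed, stays open; an unsubstituted phenyl on the same nitrogen would divide the two, and a benzyl would test whether the ring must sit directly on that nitrogen. From the compounds shown here alone, it also stays open whether any other group at this place, such as a longer alkyl chain ending in an amine, would move the number clearly away from those of compound 2 and compound 4.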